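This account rests on a few compounds, and the source may have more. Where it says the series, first, only, none or still open, it means among the compounds named here.

Compound 1 `O=C(O)CCC(=O)Nc1nc2ccc(NC(=O)c3c(Cl)cccc3Cl)cc2s1`. In a functional assay on WI-38 VA13 cells (Homo sapiens) for cytotoxicity (on this read-out higher numbers stand for an effect only at larger amounts of compound and lower numbers for an effect already at smaller amounts), compound 1 gives > 6.6 ug/mL, which is a limit of the assay.
Compound 2 `COC(=O)Nc1nc2ccc(NC(=O)c3c(Cl)cccc3Cl)cc2s1`. In this assay compound 2 gives 0.0095 ug/mL.

For the measured compounds named here, compound 2 thus holds the only number in this assay, the other result being a limit (the limit of > 6.6 ug/mL in this assay, at which 1 of the 2 values shown sits). Compound 3 `CCCOC(=O)Nc1nc2ccc(NC(=O)c3c(Cl)cccc3Cl)cc2s1` differs from compound 2 by ethyl in place of hydrogen on a saturated chain carbon bound to an oxygen next to a carbonyl group. Going by the values given here, the only measured step, an at least 690-fold lower number from compound 1 to compound 2 (2.84 log units; beyond the scatter), exchanges the whole group on the carbonyl carbon and does not directly bear on lengthening the chain beyond the oxygen. A step within the scatter is therefore expected, a 1.6-fold higher number from compound 2 to compound 3 (0.20 log units; within the scatter). Compound 3 is estimated at 0.015 ug/mL, with a range from 0.004 ug/mL to 0.06 ug/mL.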

Compound 3, half-maximal effective concentration: 0.0025 ug/mL
Estimate against measurement, compound 3: 6.0-fold (0.78 log units) above; measured number below the stated range.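

In this assay, the group on the oxygen is not silent: going from methoxy to propoxy gives a 3.8-fold lower number from compound 2 to compound 3 (0.58 log units; beyond the scatter) and so shows that this position alone shifts the number, which the earlier exchange of the whole group on the carbonyl carbon could not separate. The wider step, an at least 2600-fold lower number from compound 1 to compound 3 (3.42 log units; beyond the scatter) and no exact size, rests on the value of compound 1, which is a limit: the limit of > 6.6 ug/mL in this assay, at which 1 of the 3 values shown sits. Still open, as far as these compounds go, is whether a longer chain such as butoxy lowers the number further or raises it again, and how an amine in place of propoxy on the carbonyl carbon would read.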